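Swapping the Thiazole Sulfonyl Group for a Bromophenyl

The source may hold more compounds than are shown below. What is called first, only, known or untested is meant among the compounds shown, and "the series" means these compounds.

Measured compounds in a functional assay on DLD-1 cells (Homo sapiens) for antiproliferative activity, read by CellTiter-Glo, with a stated time of 72 h; a lower number here means a stronger inhibitor, a higher number a weaker inhibitor:
Compound 1, `Cc1cc(C)c(S(=O)(=O)N2CCC(C3OCC(C)CO3)CC2)c(C)c1`, gives > 5000 nM, which is a limit of the assay rather than a number.
Compound 2, `Cc1nc(Cl)sc1S(=O)(=O)N1CCC(N2CCC(C)CC2)CC1`, gives 1.6 nM.
Compound 3, `Cc1ccc(C2CCN(S(=O)(=O)c3c(C)cc(C)cc3C)CC2)cc1`, gives 2200 nM.

Of the two numbers shown, compound 2 has the lowest and is therefore the strongest inhibitor of this small set, with compound 3 standing far above it. Compound 4, `CC1CCN(C2CCN(S(=O)(=O)c3ccccc3Br)CC2)CC1`, has not yet been measured. It differs from compound 2 in one place: 2-bromophenyl in place of 2-chloro-4-methyl-1,3-thiazol-5-yl on a sulfonyl sulfur.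

Within the data shown here, the only measured step, an at least 2.2-fold lower number from compound 1 to compound 3 (0.35 log units; beyond the scatter), changes a group on a saturated ring carbon, not the aromatic group on the sulfonyl sulfur, so it does not bear directly on this change. Among the measured compounds shown here, no measured pair differs only at the sulfonyl aryl. Compound 3, which also carries a six-membered aromatic ring of carbon only on its sulfonyl sulfur, gives a much higher number than compound 2, but it differs from compound 2 elsewhere as well, so the comparison is indirect.

Some loss of potency is therefore expected, of moderate size rather than a collapse. For compound 4 the estimate in this assay is 30 nM, with a likely range from 3 nM to 300 nM. This estimate corresponds to an expected step of a 19-fold higher number from compound 2 to compound 4 (1.27 log units; beyond the scatter).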

Compound 4, half-maximal inhibitory concentration: 3 nM
Compound 4: the middle estimate sits 10-fold (1.00 log units) above what was measured; measured number inside the range.
By their numbers in this assay, from the lowest: compounds 2 and 4 (each within the scatter of the next); then compound 3. At a limit, above all of these: compound 1.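

In this assay, among these compounds, putting 2-bromophenyl in place of 2-chloro-4-methyl-1,3-thiazol-5-yl on the sulfonyl sulfur gives a 1.9-fold higher number from compound 2 to compound 4 (0.27 log units; within the scatter), which provides the first direct reading of a change at this position and shows that the two groups cannot be told apart in this assay. The thiazole ring is therefore not required for a low number on this shared core: a six-membered aromatic ring of carbon only does as well here, and the 2 hydrogen-bond acceptors counted on the leaving group are not needed, since the entering group has 0. Nothing among the measurements shown explains why these two different groups give matching results.

As far as these compounds go, with only these two groups compared at this position, it remains open whether the bromine itself matters, and a plain phenyl ring, a phenyl ring carrying chlorine or a methoxy group instead of bromine, or a pyridine ring could each answer that. From the compounds shown here alone, it is also open whether compound 2 and compound 4 would stay this close in cells other than the single line tested here.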